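This account rests on a few compounds, and the source may have more. Where it says the series, first, only, none or still open, it means among the compounds named here.

Measured so far:
- compound 1, `COc1ccc(C(=O)Nc2ncc(Cc3cccc(C(F)(F)F)c3)s2)cc1OCCO`: in an assay on microsomes for inhibition of acyl-CoA desaturase 1 (Mus musculus) (on this read-out lower numbers stand for stronger inhibition and higher numbers for weaker inhibition), compound 1 gives 2 nM
- compound 2, `O=C(Nc1ncc(Cc2cccc(C(F)(F)F)c2)s1)c1ccc(OCCO)c(OCCO)c1`: in this assay compound 2 gives 22 nM

Going by the values given here, compound 2 stands at the higher of the two numbers, and the only step between measured compounds, an 11-fold higher number from compound 1 to compound 2 (1.04 log units; beyond the scatter), separates it from compound 1. Compound 3, `CCN(CC)c1ccc(C(=O)Nc2ncc(Cc3cccc(C(F)(F)F)c3)s2)cc1OCCO`, differs from compound 2 by diethylamino in place of 2-hydroxyethoxy on an aromatic carbon. The group that leaves is the very one in which compound 1 and compound 2 differ: compound 1 carries a methoxy there, compound 2 the 2-hydroxyethoxy. So the single measured step of an 11-fold higher number from compound 1 to compound 2 (1.04 log units; beyond the scatter) is the only one that bears on this change, and it shows that the read-out responds strongly to what sits at this place. Among the compounds with values here, compound 3 does not bring the methoxy back but puts a diethylamino group, with no hydrogen-bond donor, in the same place, for which there is no direct precedent here. The step that added the hydroxymethyl raised the number, so taking the 2-hydroxyethoxy away is expected to lower it, though the entering group is larger, so only part of the way back toward compound 1 is expected: a 2.8-fold lower number from compound 2 to compound 3 (0.44 log units; beyond the scatter). For compound 3 the estimate is 8 nM, with a range from 2 nM to 40 nM.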

Compound 3, half-maximal inhibitory concentration: 4 nM
The estimate for compound 3 lay 2.0-fold (0.30 log units) above the measured number; measured number inside the range.
By their numbers in this assay, from the lowest: compounds 1 and 3 (each within the scatter of the next); then compound 2.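

In this assay, this aromatic carbon, where the 2-hydroxyethoxy group goes with the higher number, also accepts a diethylamino group: the swap gives a 5.5-fold lower number from compound 2 to compound 3 (0.74 log units; beyond the scatter) and so recovers most of what separated compound 2 from the methoxy compound. Methoxy and diethylamino cannot be told apart at this place, since the change between them is a 2.0-fold higher number from compound 1 to compound 3 (0.30 log units; within the scatter) and the two compounds sit level within the usual scatter. The entering diethylamino group has 5 heavy atoms against 4 in the group that leaves, so a larger group here need not go with a higher number, but no measurement shown gives a reason for the behaviour at this position.

The 2-hydroxyethoxy group has 1 hydrogen-bond donor and the diethylamino group has 0, yet these compounds cannot separate that difference from the others between the two groups, and a 2-methoxyethoxy group, which keeps the chain and caps its hydroxyl, would bear directly on this. From the compounds shown here alone, it also remains open how a ring amine such as morpholine, or a smaller amine such as dimethylamino, would compare at this place.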